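The source may report more compounds than this note shows. Statements on the series, on what has been measured and on what is new or still open speak of the compounds shown alone.

In a functional assay on HL-60 cells (Homo sapiens) for antiproliferative activity, read by MTT assay, with a stated time of 48 h (a lower number here means a stronger inhibitor, a higher number a weaker inhibitor), compound 1 (`CC(=O)OC/C1=C/C[C@](C)(CCC=C(C)C)/C=C/[C@@H](OC(=O)C=C(C)C)[C@](C)(O)/C=C/C1=O`) gives 2950 nM. Compound 2 (`CC(=O)OC/C1=C/C[C@](C)(CCC=C(C)C)/C=C/[C@@H](OC(=O)C=C(C)C)[C@](C)(OC(C)=O)/C=C/C1=O`) gives 3480 nM and compound 3 (`C=C1/C=C/C(=O)/C(CO)=C\C[C@](C)(CCC=C(C)C)/C=C/[C@H]1OC(=O)C=C(C)C`) gives 2810 nM, so compound 1 stands level with both, within the scatter. Compound 4 (`CC(C)=CCC[C@]1(C)/C=C/[C@@H](OC(=O)C=C(C)C)[C@](C)(O)/C=C/C(=O)/C(CN2CCCC2)=C\C1`) keeps the core of compound 1 but carries pyrrolidin-1-yl in place of acetoxy on a saturated chain carbon bound to a double-bonded ring carbon. Within the data shown here, the one measured single-place step, a 1.2-fold higher number from compound 1 to compound 2 (0.07 log units; within the scatter), adds acetyl on an oxygen at a different site, so it bears only indirectly. Among the measured compounds shown here, no measured step makes this exchange. With nothing larger shown, no change beyond the scatter is expected, an estimated 1.2-fold lower number from compound 1 to compound 4 (0.07 log units; within the scatter). For compound 4 the expected value is 2500 nM, with an estimated range of 700 nM to 8000 nM.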

Compound 4, half-maximal inhibitory concentration: 160 nM
Estimate against measurement, compound 4: 16-fold (1.19 log units) above; the measured number lies below the stated range.
By their numbers in this assay, from the lowest: compound 4; then compounds 3, 1 and 2 (each within the scatter of the next).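

In this assay, pyrrolidin-1-yl in place of acetoxy on a saturated chain carbon bound to a double-bonded ring carbon gives an 18-fold lower number from compound 1 to compound 4 (1.27 log units; beyond the scatter). Among these compounds, the earlier compounds stood within the scatter of one another, so this is the first sign that the number responds strongly to a change at this place. No measurement at hand accounts for the size of this step.

The compounds shown leave open whether diethylamino, an open-chain amine, or morpholin-4-yl at this place would give a similar number. Also open, on these data alone, is whether the same exchange would have a similar effect on the core of compound 2.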